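The source may hold more compounds than are shown below. What is called first, only, known or untested is meant among the compounds shown, and "the series" means these compounds.

Measured compounds:
compound 1 `NCc1cc(Oc2cccc(C(=O)N3CC[C@@H](N)C3)c2)nc(C(F)(F)F)c1`: 1230 nM
compound 2 `NCc1cc(O[C@H]2CCCN(C(=O)Nc3ccccc3)C2)nc(C(F)(F)F)c1`: 30000 nM

In an ADME assay on the whole organism (lung, Mus musculus) for pharmacokinetics, read by LC-MS, at a dose of 30 mg/kg by the oral route (on this read-out lower numbers stand for lower exposure and higher numbers for higher exposure at the dose given), compound 1 gives 1230 nM, the lower of the two numbers. Compound 2, with its differently built linker, gives 30000 nM in this assay, a gap well beyond the usual scatter. Within the data shown here, no single step between these two is defined, so only the two values themselves can be compared.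

Compound 3 `NCc1cc(Oc2cccc(C(=O)NC[C@@H](O)CO)c2)nc(C(F)(F)F)c1` has not yet been measured. It differs from compound 1 in one place: (2,3-dihydroxypropyl)amino in place of 3-aminopyrrolidin-1-yl on a carbonyl carbon. Among the measured compounds shown here, no measured pair of compounds shows this exact change, so its effect on exposure is not known from the data.

An expected step from compound 1 to compound 3 is a 2.0-fold higher number from compound 1 to compound 3 (0.31 log units; beyond the scatter), a modest rise that may sit within the scatter. On that basis compound 3 is estimated at 2500 nM in this assay, within a range of 600 nM to 10000 nM.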

Compound 3, maximal plasma concentration: 1920 nM
Estimate against measurement, compound 3: 1.3-fold (0.11 log units) above; low and high end bracket the measured number.
By their numbers in this assay, from the lowest: compounds 1 and 3 (each within the scatter of the next); then compound 2.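

Placing (2,3-dihydroxypropyl)amino in place of 3-aminopyrrolidin-1-yl on the carbonyl carbon gives a 1.6-fold higher number from compound 1 to compound 3 (0.19 log units; within the scatter) in this assay, so the two compounds cannot be told apart on this read-out. At this position, then, a ring can give way to an open chain, and the count of hydrogen-bond donors can go from 1 to 3, without a change beyond the scatter. No measured property of these groups is available to explain this result.

This single step cannot show whether the ring, the nitrogen in the ring or the two oxygen atoms of the chain matter for exposure. It also leaves open whether a carboxylic acid or a longer chain on the same carbonyl carbon would give a number in this range.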